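This account rests on a few compounds, and the source may have more. Where it says the series, first, only, none or still open, it means among the compounds named here.

Compound 3 `COc1ccccc1CN1CCN(c2ccc(C(=O)NS(=O)(=O)c3ccc(N[C@H](CCN(C)C)CSc4ccccc4)c([N+](=O)[O-])c3)cc2)CC1` sits second highest of the three numbers recorded in an assay on isolated protein for displacement of a labelled ligand from Apoptosis regulator Bcl-2 (Homo sapiens), read by fluorescence polarization; a lower number here means a stronger inhibitor, a higher number a weaker inhibitor. In this assay compound 3 gives 3.2 nM, compound 2 `CC1OC2(CCN(c3ccc(C(=O)NS(=O)(=O)c4ccc(N[C@H](CCN(C)C)CSc5ccccc5)c([N+](=O)[O-])c4)cc3)CC2)N(Cc2ccccc2)C1=O` gives 9.6 nM, and compound 1 `CN(C)CC[C@H](CSc1ccccc1)Nc1ccc(S(=O)(=O)NC(=O)c2ccc(N3CCC(=Cc4ccccc4Cl)CC3)cc2)cc1[N+](=O)[O-]` gives 0.7 nM, so compound 3 lies between the other two, with both gaps beyond the usual scatter. Compound 4 `CN(C)CC[C@H](CSc1ccccc1)Nc1ccc(S(=O)(=O)NC(=O)c2ccc(N3CCN(Cc4ccccc4-c4ccc(S(C)(=O)=O)cc4)CC3)cc2)cc1[N+](=O)[O-]` differs from compound 3 by one change: 4-(methylsulfonyl)phenyl in place of methoxy on an aromatic carbon. Among the compounds with values here, no measured pair in this set shows the effect of such a change, so there is nothing to anchor the direction. The expectation is therefore that the step from compound 3 to compound 4 in this assay, a 1.3-fold higher number from compound 3 to compound 4 (0.10 log units; within the scatter), stays within the scatter. On that basis compound 4 is estimated to give 4 nM in this assay, with a range from 1.2 nM to 15 nM.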

Compound 4, inhibition constant: < 1 nM
Compound 4 ended at the assay's limit (the forecaster's own chance of this, stated with the estimate: 2%); middle value at least 4.0-fold (0.60 log units) from the limit.
By their numbers in this assay, from the lowest: compound 1; then compound 3; then compound 2.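

The change from methoxy to 4-(methylsulfonyl)phenyl on an aromatic carbon, ortho to a large group, brings an at least 3.2-fold lower number from compound 3 to compound 4 (0.50 log units; beyond the scatter) in this assay. This position therefore takes a far larger group carrying an added aromatic ring, and the number still falls. Compound 4 gives < 1 nM, which is a limit of the assay, so the full size of the step cannot be read: the limit of < 1 nM in this assay, at which 1 of the 4 values shown sits.

Going by these compounds, it remains open which part of the entering group carries the step, the aromatic ring or the methylsulfonyl on it. On these data alone, it is also open whether a plain phenyl, or a phenyl bearing an amine or a carboxylic acid, would serve this position equally well.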